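Swapping (4-Fluorophenyl)sulfanyl for (4-Fluorobenzyl)amino

This account rests on a few compounds, and the source may have more. Where it says the series, first, only, none or still open, it means among the compounds named here.

Compound 1 `Nc1cc(N)c2nc(-c3ccccc3)c(Sc3ccc(F)cc3)nc2c1` was tested in a functional assay on ACHN cells (Homo sapiens) for inhibition, read by sulforhodamine B assay, with a stated time of 48 h; a lower number here means a stronger inhibitor of growth, a higher number a weaker inhibitor of growth. In this assay compound 1 reaches only a limit of the assay, < 100000 nM, so no number is known for it, as the limit of < 100000 nM in this assay, at which 1 of the 3 values shown sits, records. Two further compounds share the same core and carry other groups at the same place. Compound 2 `COc1cc(CNc2nc3cc(N)cc(N)c3nc2-c2ccccc2)cc(OC)c1OC` gives 11200 nM in this assay, and compound 3 `CCOC(=O)[C@H](CCC(=O)O)NC(=O)c1ccc(Oc2nc3cc(N)cc(N)c3nc2-c2ccccc2)cc1` gives 11200 nM in this assay. These two values lie within the scatter of each other, so nothing separates them.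

Compound 4 `Nc1cc(N)c2nc(-c3ccccc3)c(NCc3ccc(F)cc3)nc2c1` differs from compound 1 in one place: (4-fluorobenzyl)amino in place of (4-fluorophenyl)sulfanyl on an aromatic carbon. Within the data shown here, no two measured compounds here differ in a single place, so no step of known size can be drawn on. Compound 2 and compound 3 give numbers rather than limits, which suggests that a group joined through nitrogen at this place can yield a measurable value. Compound 4 is therefore expected to land at 15000 nM, within a range from 4000 nM to 60000 nM. The expected step that the limit leaves unreadable from compound 1 to compound 4 is thus estimated to stay moderate and cannot be set against more than a limit.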

Compound 4, concentration for total growth inhibition: 3090 nM
Compound 4: middle estimate off by 4.9-fold (0.69 log units), on the high side, and the stated range ends above it.
By their numbers in this assay, from the lowest: compound 4; then compounds 2 and 3 (each within the scatter of the next).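

Among these compounds, no step from compound 1 to compound 4 can be read in this assay, because compound 1 gives only a limit of the assay: the limit of < 100000 nM in this assay, at which 1 of the 4 values shown sits. From the compounds shown here alone, the size of the change from (4-fluorophenyl)sulfanyl to (4-fluorobenzyl)amino on the shared core stays open.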